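Trifluoromethyl for Fluoro: Another Cytotoxicity Limit Expected

The source may report more compounds than this note shows. Statements on the series, on what has been measured and on what is new or still open speak of the compounds shown alone.

Compound 1 `FC(F)(F)c1ccc(C2CC(c3ccccc3)=NN2c2ccc(-c3ccccc3)nn2)cc1` and compound 2 `Fc1ccc(C2CC(c3ccc(Cl)cc3)=NN2c2ccc(-c3ccccc3)nn2)cc1` share a core and were both tested in an ADME assay on HEK293 cells (Homo sapiens) for cytotoxicity, read by MTT assay, with a stated time of 24 h; a higher number here means a weaker inhibitor, a lower number a stronger inhibitor. Compound 1 gave only > 300000 nM, which is a limit of the assay and not a number. Compound 2 likewise gave > 300000 nM, again a limit rather than a number. Both sit at the limit of > 300000 nM in this assay, at which 2 of the 2 values shown sit, so compound 2 stands level with compound 1, with no measurable cytotoxicity. Compound 3 `FC(F)(F)c1ccc(C2CC(c3ccc(Cl)cc3)=NN2c2ccc(-c3ccccc3)nn2)cc1` differs from compound 2 by trifluoromethyl in place of fluoro on an aromatic carbon. Among the measured compounds shown here, no measured step of this kind exists here, so no change beyond the scatter is expected. The expected step is a number no higher from compound 2 to compound 3 (the limit leaves the size open), essentially none. Compound 3 is therefore expected to give 300000 nM, within 100000 nM to 1000000 nM, most likely again as a limit.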

Compound 3, half-maximal inhibitory concentration: > 300000 nM
Compound 3 was reported as a limit (the forecaster's own chance of this, stated with the estimate: 85%); the middle value lies on the limit itself.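

No step can be read between compound 1, compound 2 and compound 3 in this assay because each result is a limit of the assay, not a number: the limit of > 300000 nM in this assay, at which 3 of the 3 values shown sit.

Still open, on these data alone, is whether swapping fluoro for trifluoromethyl, or hydrogen for chloro, changes cytotoxicity at all.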